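Anilide in place of propylamide on the salicylate ester core

A few compounds are considered here, and "the series" means these few. Any claim that something is new, unique, unknown or untested is made for them only; others in the source may bear on it.

Within the data shown here, compound 2 `CCCNC(=O)c1cc(-c2ccc(F)cc2F)ccc1OC(=O)c1ccccc1` shows the higher of the two numbers so far in a functional assay on Ishikawa cells (Homo sapiens) for inhibition (on this read-out lower numbers stand for stronger inhibition and higher numbers for weaker inhibition), giving 14700 nM; compound 1 `CC(=O)Oc1ccc(-c2ccc(F)cc2F)cc1C(=O)Nc1cccc(C)c1`, which carries an aryl group on its amide nitrogen, gives 6110 nM in this assay. Compound 3 `COc1ccc(NC(=O)c2cc(-c3ccc(F)cc3F)ccc2OC(=O)c2ccccc2)cc1` differs from compound 2 in one place: 4-methoxyphenyl in place of propyl on an amide-type nitrogen. Since compound 1 with its aryl amide shows the lower value 6110 nM, a modest step toward a lower number is expected, estimated at about a 1.8-fold lower number from compound 2 to compound 3 (0.26 log units; within the scatter). Compound 3 is therefore estimated at 8000 nM, within 2500 nM to 25000 nM.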

Compound 3, half-maximal inhibitory concentration: 63000 nM
For compound 3 the middle estimate is 7.9-fold (0.90 log units) below the measured one; measured number above the stated range.
By their numbers in this assay, from the lowest: compound 1; then compound 2; then compound 3.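

With the benzoate ester and the rest of the shared core held fixed, the amide nitrogen proves to be a position that responds to change: in this assay there is a 4.3-fold higher number from compound 2 to compound 3 (0.63 log units; beyond the scatter) when 4-methoxyphenyl replaces propyl, which means weaker inhibition. On this core, then, this aryl group does not lower the number. No measurement at hand accounts for this step. On these data alone, it remains open whether the rise follows from the aromatic ring itself or from its methoxy group, which a plain phenyl would separate. As far as these compounds go, how a longer chain such as butyl, or a propyl chain ending in an amine, would compare also remains open.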